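Dropping the Chloro Group: Compound 3 to Compound 4

The compounds below may be only part of what the source reports. "The series", "measured", "known", "first", "only" and "open" are said of these compounds alone.

Among the three measured compounds, compound 3 `COc1cc(C2=CC3CNCC(C2)C3)cnc1Cl` gives the lowest number in an in vitro assay on SH-SY5Y cells for displacement of a labelled ligand from Neuronal acetylcholine receptor; alpha3/beta4 (Homo sapiens) (a higher number here means a weaker inhibitor, a lower number a stronger inhibitor), at 7 nM, with both other compounds beyond the usual scatter. Compound 2 `COc1ccccc1Oc1cncc(C2=CC3CNCC(C2)C3)c1` gives 56 nM, and compound 1 `COc1cc(C2=CC3CC(C2)CN(C)C3)cnc1Cl` gives 1430 nM. Among the compounds with values here, the only measured single-place step, a 200-fold lower number from compound 1 to compound 3 (2.31 log units; beyond the scatter), concerns the amine nitrogen in the ring, not the aromatic part. Compound 4 `COc1cncc(C2=CC3CNCC(C2)C3)c1` differs from compound 3 by hydrogen in place of chloro on an aromatic carbon; the chloro sits next to the ring nitrogen and ortho to the methoxy group. Within the data shown here, no measured step touches this position, so the expectation rests on thin ground. A modest rise in the number is expected, with a 5.7-fold higher number from compound 3 to compound 4 (0.76 log units; beyond the scatter). Compound 4 is estimated at 40 nM, within a range from 10 nM to 150 nM.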

Compound 4, inhibition constant: 14.3 nM
Compound 4: middle estimate off by 2.8-fold (0.45 log units), on the high side; measured number inside the range.
By their numbers in this assay, from the lowest: compound 3; then compound 4; then compound 2; then compound 1.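

Replacing chloro with hydrogen on this aromatic carbon, next to the ring nitrogen, gives a 2.0-fold higher number from compound 3 to compound 4 (0.31 log units; beyond the scatter) in this assay, a real but modest change, so binding does not depend on chloro. On the oxygen, methyl in place of 2-methoxyphenyl gives a 3.9-fold lower number from compound 2 to compound 4 (0.59 log units; beyond the scatter), so the 2-methoxyphenyl group is not needed for binding either. No available evidence explains these steps. On these data alone, whether fluoro, a nitrile or an amine on this carbon would match chloro remains open. So does the effect of an ethyl group on the oxygen.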